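From Cyano to Sulfamoyl: A Clearance Question

A few compounds are considered here, and "the series" means these few. Any claim that something is new, unique, unknown or untested is made for them only; others in the source may bear on it.

Two compounds have so far been followed in an ADME assay on the whole organism (plasma) for pharmacokinetics, with Rattus norvegicus as the target, at a dose of 0.2 mg/kg by the intravenous route; a lower number here means slower removal, a higher number faster removal of the compound. Compound 1 `NS(=O)(=O)c1ccc(OCCCN2CCC(C(O)(c3cccc(F)c3)c3nccs3)CC2)cc1` gives 26 mL/min/kg, and compound 2 `N#Cc1ccc(OCCCN2CCC(C(O)(c3ccccn3)c3nccs3)CC2)cc1` gives 12 mL/min/kg. Compound 2 therefore holds the lower of the two numbers, and the gap between them lies beyond the scatter of repeated measurements.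

Compound 3 `NS(=O)(=O)c1ccc(OCCCN2CCC(C(O)(c3ccccn3)c3nccs3)CC2)cc1` keeps the structure of compound 2 except for one group: sulfamoyl in place of cyano on an aromatic carbon, para to a large group (sulfamoyl in place of cyano on an aromatic carbon). Among the measured compounds shown here, changing a single group while the rest stays fixed gives the cleanest comparison, but no measured pair yet shows this change alone. For the measured compounds named here, the only measured sulfamoyl example, which differs from compound 3 elsewhere in the molecule, is compound 1 at 26 mL/min/kg, so it is only a loose guide. A slight lean upward in this assay is expected, though nothing beyond the scatter, with an estimated step of a 1.3-fold higher number from compound 2 to compound 3 (0.12 log units; within the scatter). For compound 3 the estimated clearance is 16 mL/min/kg, with an expected range of 8 mL/min/kg to 30 mL/min/kg.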

Compound 3, clearance: 32 mL/min/kg
For compound 3 the middle estimate is 2.0-fold (0.30 log units) below the measured one; measured number outside the range, above it.
By their numbers in this assay, from the lowest: compound 2; then compounds 1 and 3 (each within the scatter of the next).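

In this assay, the swap of cyano for sulfamoyl can now be read on its own, with everything else held fixed: a 2.7-fold higher number from compound 2 to compound 3 (0.43 log units; beyond the scatter), a step beyond the scatter. This place, on an aromatic carbon para to a large group, therefore matters for how fast the rat removes the compound. With sulfamoyl held fixed, pyridin-2-yl in place of 3-fluorophenyl gives a 1.2-fold higher number from compound 1 to compound 3 (0.09 log units; within the scatter), which stays within the scatter, so that second place shows no readable effect here. Among these three compounds, only the sulfamoyl-for-cyano change carries a step that clearly exceeds the noise of the measurement.

On these data alone, whether a carboxamide or a methylsulfonyl group at this same place would land nearer compound 2 or compound 3 stays open, as does whether the same step would appear with 3-fluorophenyl in the molecule instead of pyridin-2-yl. No measurement at hand bears on what lies behind the step.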